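The source may report more compounds than this note shows. Statements on the series, on what has been measured and on what is new or still open speak of the compounds shown alone.

In an ADME assay on CCRF-HSB-2 cells (Homo sapiens) for cytotoxicity, with a stated time of 7 days (on this read-out lower numbers stand for higher toxicity in this test and higher numbers for lower toxicity in this test), compound 3 `CCCOc1nc(N)nc2c1ncn2/C=C1/CC1(CO)CO` stands only at a limit of the assay, giving > 20000 nM. Compound 1 `CCCCCCCCOc1nc(N)nc2c1ncn2/C=C1/CC1(CO)CO` gives a limit as well in this assay, namely > 20000 nM. Compound 2 `CCCNc1nc(N)nc2c1ncn2/C=C1/CC1(CO)CO` likewise reaches only a limit in this assay, > 20000 nM. The steps among these three, a step that the two limits leave unreadable from compound 1 to compound 2, a step that the two limits leave unreadable from compound 1 to compound 3 and a step that the two limits leave unreadable from compound 2 to compound 3, run between limits and give no readable size, because of the limit of > 20000 nM in this assay, at which 3 of the 3 values shown sit. Compound 4 `Nc1nc(OCC(F)(F)F)c2ncn(/C=C3/CC3(CO)CO)c2n1` differs from compound 3 by trifluoromethyl in place of ethyl on a saturated chain carbon bound to an oxygen on an aromatic ring. Within the data shown here, none of the measured steps bears readably on this change, so neither direction nor size can be drawn from them. Compound 4 is therefore expected to sit again at or near the limit in this assay, with an estimated value of 30000 nM in a range from 10000 nM to 100000 nM, which means an expected step that the limit leaves unreadable from compound 3 to compound 4.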

Compound 4, half-maximal cytotoxic concentration: > 20000 nM
Compound 4: no number, only a limit (the forecaster's own chance of this, stated with the estimate: 80%); the middle value does not contradict the limit.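

Among these compounds, no step involving compound 4 can be read, as compound 1, compound 2, compound 3 and compound 4 all give only a limit, because of this: the limit of > 20000 nM in this assay, at which 4 of the 4 values shown sit. The compounds shown leave open whether any of these side-chain changes alters toxicity in this assay at all.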